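The source may hold more compounds than are shown below. What is called first, only, known or untested is meant among the compounds shown, and "the series" means these compounds.

Measured compounds:
Compound 1, `Cc1c(C(=O)NCc2cccc(C(F)(F)F)c2)cnn1-c1ccccc1`: in a functional assay on cells for antagonist activity at C-C chemokine receptor type 1 (Homo sapiens), read by FLIPR and calcium flux (on this read-out lower numbers stand for stronger inhibition and higher numbers for weaker inhibition), compound 1 gives > 3000 nM, which is a limit of the assay rather than a number.
Compound 2, `Cc1c(C(=O)NCc2cccc(C(F)(F)F)c2)cnn1-c1ccc(Cl)cc1`: compound 2 gives 600 nM.
Compound 3, `Cc1cccc(-n2ncc(C(=O)NCc3cccc(C(F)(F)F)c3)c2C)c1`: compound 3 gives > 3000 nM, again a limit of the assay and not a number.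

Compound 3 therefore stands at the weak end of what has been measured, since an at least 5.0-fold higher number from compound 2 to compound 3 (0.69 log units; beyond the scatter) separates it from compound 2 and it sits at the limit of > 3000 nM in this assay, at which 2 of the 3 values shown sit.

Compound 4, `Cc1c(C(=O)NCc2cccc(C(F)(F)F)c2)cnn1Cc1ccccc1`, differs from compound 3 by benzyl in place of 3-methylphenyl on an aromatic nitrogen. Among the measured compounds shown here, two measured steps touch the same aromatic nitrogen and the group on it: an at least 5.0-fold lower number from compound 1 to compound 2 (0.69 log units; beyond the scatter) and an at least 5.0-fold higher number from compound 2 to compound 3 (0.69 log units; beyond the scatter), both beyond the scatter, while a step that the two limits leave unreadable from compound 1 to compound 3 cannot be read. None of them exchanges an aryl group for a benzyl group, so the direction of the new step cannot be read from them. With compound 3 already at a limit, the step from compound 3 to compound 4 is expected to be a step that the limit leaves unreadable from compound 3 to compound 4, most likely ending at the limit again. Compound 4 is thus estimated at 5000 nM, within a range from 1500 nM to 30000 nM.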

Compound 4, half-maximal inhibitory concentration: > 3000 nM
Compound 4 ended at the assay's limit (the forecaster's own chance of this, stated with the estimate: 70%); the middle value is on the limit's open side.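

In this assay, putting benzyl in place of 4-chlorophenyl on the aromatic nitrogen gives an at least 5.0-fold higher number from compound 2 to compound 4 (0.69 log units; beyond the scatter). So among the four groups shown at this position, 4-chlorophenyl remains the only one with a reading inside the range of the assay, and moving the ring off the nitrogen onto a single carbon, as benzyl does, does not change that. The steps to compound 4 from compound 1 and from compound 3 cannot be read, because all three compounds rest on the same limit: the limit of > 3000 nM in this assay, at which 3 of the 4 values shown sit.

From the compounds shown here alone, how phenyl, 3-methylphenyl and benzyl rank against one another therefore stays open. Also open, going by these compounds, is whether 4-chlorobenzyl, which puts the chloro onto the benzyl ring, would read like compound 2 or like compound 4, and what a longer chain such as 2-phenylethyl would do.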